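Chloro substitution on the shared purine-like core, the third isomer series

The compounds below may be only part of what the source reports. "The series", "measured", "known", "first", "only" and "open" are said of these compounds alone.

Measured so far in a functional assay on PC-3 cells (Homo sapiens) for cytotoxicity, read by sulforhodamine B assay, with a stated time of 48 h; on this read-out lower numbers stand for higher toxicity in this test and higher numbers for lower toxicity in this test:
Compound 1 `ClCc1ccc(Cn2cnc3c(Cl)ncnc32)cc1` gives > 100000 nM, which is a limit of this assay and not a number.
Compound 2 `ClCc1cccc(Cn2cnc3ncnc(Cl)c32)c1` gives 63100 nM.
Compound 3 `ClCc1cccc(Cn2cnc3c(Cl)ncnc32)c1` gives 67600 nM.

Compound 3 and compound 2 lie within the usual scatter of each other, so no order between them can be read; the value of compound 1 is a limit. Compound 4 `ClCc1cccc(Cn2cnc3c(Cl)nc(Cl)nc32)c1` differs from compound 3 by chloro in place of hydrogen on an aromatic carbon. Within the data shown here, no measured pair in the set isolates this change, so its effect has no reference here. The step from compound 3 to compound 4 is expected to be small, near the scatter, with a lean toward a lower number, as a 1.5-fold lower number from compound 3 to compound 4 (0.18 log units; within the scatter). Compound 4 is therefore estimated at 45000 nM, between 18000 nM and 100000 nM.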

Compound 4, concentration lethal to 50% of the cells: 55000 nM
Beside the measured number, compound 4's estimate is 1.2-fold (0.09 log units) below it, within the range that was stated.
By their numbers in this assay, from the lowest: compounds 4, 2 and 3 (each within the scatter of the next). At a limit, above all of these: compound 1.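

In this assay chloro in place of hydrogen on an aromatic carbon between two ring nitrogen atoms gives a 1.2-fold lower number from compound 3 to compound 4 (0.09 log units; within the scatter) and so stays within the scatter at this position. Among these compounds, this is the first step that isolates one change, and it shows no measurable effect of the added chloro. Compound 1 remains a limit and not a number: the limit of > 100000 nM in this assay, at which 1 of the 4 values shown sits.

Going by these compounds, whether an amine, a methoxy group or a longer chain at this position would move the number beyond the scatter stays open. Also open, on these data alone, is whether the same chloro step would read alike on the cores of compound 1 and compound 2.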